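A Hydroxy Group Added to the Benzyl of Compound 2

The compounds below may be only part of what the source reports. "The series", "measured", "known", "first", "only" and "open" are said of these compounds alone.

compound 1: `N=C(NCc1ccc(O)cc1)[C@@H]1CCC(=O)N1Cc1ccc([N+](=O)[O-])cc1` — 34.5%
compound 2: `N=C(NCc1ccccc1)[C@@H]1CCC(=O)N1Cc1ccc(F)cc1` — 31.4%

In a functional assay on SH-SY5Y cells (Homo sapiens) for cytotoxicity, read by MTT assay, with stated times of 8 h, 30 min and 12 h, tested at 5 uM (a higher number here means a stronger effect of the compound at the concentration tested, a lower number a weaker effect), compound 2 gives 31.4%, the bottom of the two numbers shown, while compound 1 gives 34.5%, and the gap between the two lies within the scatter, so neither is told apart from the other. Compound 3, `N=C(NCc1ccc(O)cc1)[C@@H]1CCC(=O)N1Cc1ccc(F)cc1`, has not yet been measured. It differs from compound 2 in one place: hydroxy in place of hydrogen on an aromatic carbon. Among the measured compounds shown here, no pair of measured compounds differs by this change alone; compound 1 and compound 2 differ in two places at once and still sit within the scatter of each other. On that basis the step in this assay is expected to be none beyond the scatter, in either direction. The step from compound 2 to compound 3 is estimated at a number 1.6 percentage points higher from compound 2 to compound 3 (within the scatter). Compound 3 is therefore expected to give 33%, with a range from 21% to 45%.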

Compound 3, a percentage reported as activity, at one concentration (the size of the read-out at that concentration, not a potency): 48.6%
Compound 3: the middle estimate sits 15.6 percentage points below what was measured; measured number outside the range, above it.
By their numbers in this assay, from the lowest: compounds 2 and 1 (each within the scatter of the next); then compound 3.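

In this assay, hydroxy in place of hydrogen on an aromatic carbon, para to a large group, gives a number 17.2 percentage points higher from compound 2 to compound 3 (beyond the scatter), a step beyond the scatter; this change from phenyl to 4-hydroxyphenyl could not be read from compound 1 and compound 2, which differ in two places at once. With the 4-hydroxybenzyl held fixed, fluoro in place of nitro on an aromatic carbon gives a number 14.1 percentage points higher from compound 1 to compound 3 (beyond the scatter), also beyond the scatter, so the number in this assay shifts with a change in either place. Nothing available bears on why either change moves the number.

The compounds shown leave open whether a methoxy group or an amine on that aromatic carbon would match hydroxy. They also leave open whether the hydroxy step holds with nitro in place of fluoro, and how chloro would compare with fluoro.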